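Swapping an Alkyne Chain for a Saturated Octyl

The source may hold more compounds than are shown below. What is called first, only, known or untested is meant among the compounds shown, and "the series" means these compounds.

Compound 1 `CCCCC#Cc1ccc(S(=O)(=O)Nc2cccc(-c3csc(NC(C)=O)n3)c2)cc1` carries a hex-1-yn-1-yl group on a six-membered aromatic ring of carbon only. In a functional assay on A-375 cells (Homo sapiens) for antiproliferative activity, read by trypan blue exclusion, with a stated time of 48 h, tested at 10 uM (on this read-out lower numbers stand for a stronger effect and higher numbers for a weaker effect at the one concentration tested), compound 1 gives < 1% and this is a limit of the assay rather than a number. Compound 2 `CC(=O)Nc1nc(-c2cccc(NS(=O)(=O)c3ccc(C#C[Si](C)(C)C)cc3)c2)cs1` differs only in what sits on the triple-bonded carbon, a group of 4 heavy atoms (3 carbon, 1 silicon; no ring) in place of a group of 4 heavy atoms (4 carbon; no ring). In this assay compound 2 gives < 1% and this too is a limit. The step that the two limits leave unreadable from compound 1 to compound 2 therefore cannot be read in size; all that can be said is the limit of < 1% in this assay, at which 2 of the 2 values shown sit, in this assay.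

Compound 3 `CCCCCCCCc1ccc(S(=O)(=O)Nc2cccc(-c3csc(NC(C)=O)n3)c2)cc1` has not been measured. The change is octyl in place of hex-1-yn-1-yl on an aromatic carbon. For the measured compounds named here, no measured step covers this change, and the one measured step is hidden behind two limits, so nothing measured points toward a large move. The expectation for compound 3 is that it stays near the limit, with the step of a number at least 2 percentage points higher from compound 1 to compound 3 (that floor lies within the scatter) expected to be none beyond the scatter. Compound 3 is estimated at 3% in this assay, expected to lie between 0% and 20%.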

Compound 3, a percentage reported as activity, at one concentration (the size of the read-out at that concentration, not a potency): < 1%
Compound 3 ended at the assay's limit; the forecaster's own chance of this, stated with the estimate: 50%; middle value at least 2 percentage points away from the limit.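

Neither step to compound 3, from compound 1 or from compound 2, can be read in size, since all three compounds stand at a limit of the assay rather than at a number: the limit of < 1% in this assay, at which 3 of the 3 values shown sit.

As far as these compounds go, what stays open is how far apart compound 1, compound 2 and compound 3 lie in this assay and whether swapping these chains changes the effect at all.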